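A few compounds are considered here, and "the series" means these few. Any claim that something is new, unique, unknown or untested is made for them only; others in the source may bear on it.

Three related compounds have been tested in an ADME assay on HEK293 cells (Homo sapiens) for cytotoxicity, read by resazurin assay, with a stated time of 16 h; a lower number here means that less compound is needed, a higher number that more compound is needed for the effect. Compound 2 `COc1ccc(/C=C/C(=O)CC(=O)/C=C/c2ccc(OC)c(OC)c2)cc1` carries only methyl groups on its oxygens, and in this assay compound 2 gives 690000 nM. Compound 1 `COc1ccc(/C=C/C(=O)CC(=O)/C=C/c2ccc(O)c(OC)c2)cc1` differs from compound 2 by one change, (hydrogen in place of methyl on an oxygen on an aromatic ring), and compound 1 gives 79000 nM. The step is an 8.7-fold lower number from compound 2 to compound 1 (0.94 log units; beyond the scatter), which shows a clear move toward a lower number once a methyl is removed from an oxygen on an aromatic ring. Compound 3 `COc1cc(/C=C/C(=O)CC(=O)/C=C/c2ccc(OC(C)=O)cc2)ccc1OC(C)=O` has a different core from compound 2, and the difference between the two cores is not broken down here; in this assay compound 3 gives 49000 nM. Compound 3 and compound 1 give numbers that lie within the usual scatter of each other, so no order between them can be read from the data.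

Compound 4 `CC(=O)Oc1ccc(/C=C/C(=O)CC(=O)/C=C/c2ccc(OC(C)=O)c(O)c2)cc1` has not yet been measured. Going by the values given here, it differs from compound 3 by hydrogen in place of methyl on an oxygen on an aromatic ring, which is the same change, at the same kind of place, as the one that separates compound 2 from compound 1. Among the compounds with values here, on that basis a step toward a lower number is expected for compound 4, estimated as a 3.3-fold lower number from compound 3 to compound 4 (0.51 log units; beyond the scatter), because the earlier change produced an 8.7-fold lower number from compound 2 to compound 1 (0.94 log units; beyond the scatter) and only one such example exists. The expected number for compound 4 is therefore estimated at 15000 nM, likely falling between 5000 nM and 45000 nM.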

Compound 4, half-maximal effective concentration: > 500000 nM
Compound 4: no number, only a limit; the forecaster's own chance of this, stated with the estimate: 5%; at least 33-fold (1.52 log units) between middle value and limit.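

In this assay, going by these compounds alone, compound 4 gives > 500000 nM, which is a limit of the assay and not a number, and only one compound in this set sits there: the limit of > 500000 nM in this assay, at which 1 of the 4 values shown sits. Putting hydrogen in place of methyl on an oxygen on an aromatic ring, which turns methoxy to hydroxy, gives an at least 10-fold higher number from compound 3 to compound 4 (1.00 log units; beyond the scatter), so the same change points in opposite directions on the two cores: the same change on two cores in this assay, an 8.7-fold lower number (0.94 log units; beyond the scatter) from compound 2 to compound 1 and an at least 10-fold higher number (1.00 log units; beyond the scatter) from compound 3 to compound 4, at least 89-fold (1.94 log units) apart, beyond the scatter of two such steps. This shows that in this series neither the direction nor the size of the step carries over from one core to another, yet it does not show what in the cores makes the two results differ, and two pairs, one of them ending at a limit, give no rule for any further core.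

The compounds shown leave open how far above the limit compound 4 lies, and so how large its step really is, as well as which of the differences between the two cores decides the direction of the change. They also leave open what happens in this assay when that oxygen carries a longer chain such as ethyl, or when an amine or a carboxylic acid stands in place of the hydroxy group.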